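Swapping chloro for methyl on a phenoxy ring

This account rests on a few compounds, and the source may have more. Where it says the series, first, only, none or still open, it means among the compounds named here.

Compound 1, `COc1cccc(OC)c1OCCNCCOc1ccccc1OCc1ccccc1`, gives 9.37 in a functional assay on thoracic aorta (strain Wistar) for antagonist activity at Alpha-1D adrenergic receptor (Rattus norvegicus); a lower number here means a less potent compound, a higher number a more potent compound, by a factor of ten per unit of this negative logarithm.
Compound 2, `COc1cccc(Cl)c1OCCNCCOc1ccccc1OCc1ccccc1`, gives 8.74 in this assay.

Among the measured compounds shown here, compound 2 holds the lower of the two numbers, and the only measured step, a number 0.63 log units lower from compound 1 to compound 2 (beyond the scatter), is a modest loss beyond the scatter. Compound 3, `COc1cccc(C)c1OCCNCCOc1ccccc1OCc1ccccc1`, differs from compound 2 by methyl in place of chloro on an aromatic carbon. That measured step exchanged a methoxy, not a chloro, so it gives no direct guide; a step within the scatter is therefore expected, a number 0.06 log units higher from compound 2 to compound 3 (within the scatter). Compound 3 is expected to reach about 8.8, plausibly between 8.3 and 9.4.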

Compound 3, negative logarithm of the antagonist equilibrium constant: 8.36
For compound 3 the middle estimate is 0.44 log units above the measured one, within the range that was stated.
By their numbers in this assay, from the lowest: compound 3; then compound 2; then compound 1.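

At this position, methyl does not stand in for chloro: the change gives a number 0.38 log units lower from compound 2 to compound 3 (beyond the scatter) in this assay. Both replacements of methoxy now lose potency, and methyl loses more, with a number 1.01 log units lower from compound 1 to compound 3 (beyond the scatter), so the three groups rank methoxy, then chloro, then methyl. No measurement here explains this order.

Still open, going by these compounds, is how a hydroxyl, an ethoxy, a fluoro or a bromo would fare at this position. Also open, on these data alone, is whether the same order would hold if the other methoxy group on this ring were changed.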